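Aryl amide replacements on the chromone acetamide series

This account rests on a few compounds, and the source may have more. Where it says the series, first, only, none or still open, it means among the compounds named here.

Of the compounds shown here, three of the shared core have been measured in an assay on isolated protein for inhibition of Rho-associated protein kinase 2 (Homo sapiens), read by scintillation counting, radiometric assay and 33P incorporation, with a stated time of 40 min, in the presence of a further agent that is not named here; a higher number here means a weaker inhibitor, a lower number a stronger inhibitor. Compound 1 `CC(C)(C)c1ccc(C(=O)Nc2cccc(NC(=O)COc3ccc4c(=O)ccoc4c3)c2)cc1` gives 34 nM. Compound 2 `O=C(COc1ccc2c(=O)ccoc2c1)Nc1cccc(NC(=O)c2ccc(OC(F)(F)F)cc2)c1` gives 77 nM. Compound 3 `Cc1cc(C(=O)Nc2cccc(NC(=O)COc3ccc4c(=O)ccoc4c3)c2)no1` gives 5 nM, the lowest of the three numbers; the nearest is compound 1, the furthest compound 2.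

Among the compounds with values here, two steps so far change the group on the carbonyl carbon whose other neighbour is the amide-type nitrogen: a 6.8-fold lower number from compound 1 to compound 3 (0.83 log units; beyond the scatter) and a 15-fold lower number from compound 2 to compound 3 (1.19 log units; beyond the scatter). The third step, a 2.3-fold higher number from compound 1 to compound 2 (0.36 log units; beyond the scatter), changes only the substituent on the aromatic carbon of that group.

Compound 4 `Nc1cccc(C(=O)Nc2cccc(NC(=O)COc3ccc4c(=O)ccoc4c3)c2)c1` differs from compound 3 by 3-aminophenyl in place of 5-methyl-1,2-oxazol-3-yl on a carbonyl carbon. This reverses the direction of the two steps that led to compound 3, bringing back a six-membered carbon ring in place of the five-membered ring with two hetero atoms, though the aminophenyl group has no direct parallel among the measured compounds. A step back towards the numbers of compound 1 and compound 2 is therefore expected, estimated as a 6.0-fold higher number from compound 3 to compound 4 (0.78 log units; beyond the scatter) in this assay. Compound 4 is expected to give about 30 nM, with a range of 8 nM to 120 nM.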

Compound 4, half-maximal inhibitory concentration: 58 nM
Estimate against measurement, compound 4: 1.9-fold (0.29 log units) below; low and high end bracket the measured number.
By their numbers in this assay, from the lowest: compound 3; then compounds 1, 4 and 2 (each within the scatter of the next, the first and the last beyond it).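

Replacing 5-methyl-1,2-oxazol-3-yl with 3-aminophenyl on this carbonyl carbon gives a 12-fold higher number from compound 3 to compound 4 (1.06 log units; beyond the scatter) in this assay, so a third phenyl group, now with a different substituent in a different ring place and with a hydrogen-bond donor, does not recover the low number of the five-membered ring. Among the phenyl groups, the change to 3-aminophenyl stays within the scatter, with a 1.3-fold lower number from compound 2 to compound 4 (0.12 log units; within the scatter) and a 1.7-fold higher number from compound 1 to compound 4 (0.23 log units; within the scatter). Nothing available bears on why the five-membered ring stands apart.

Still open, as far as these compounds go, is whether the low number depends on the ring itself or on its methyl group, a question that unsubstituted 1,2-oxazol-3-yl on the same carbonyl carbon would address. Also open, from the compounds shown here alone, is how a pyridine ring or 4-aminophenyl would compare at this position.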